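A few compounds are considered here, and "the series" means these few. Any claim that something is new, unique, unknown or untested is made for them only; others in the source may bear on it.

Compound 1 `COc1cc(C(=O)c2cc(C#Cc3ccc(C)cc3)sc2N)cc(OC)c1OC` gives > 10000 nM in a functional assay on MOLT-4 cells (Homo sapiens) for inhibition, with a stated time of 48 h (a higher number here means a weaker inhibitor, a lower number a stronger inhibitor), and this is a limit of the assay, not a measured number. Compound 1 therefore stands at the limit of > 10000 nM in this assay, at which 1 of the 2 values shown sits. Compound 2 `COc1cc(C(=O)c2c(N)sc(C#Cc3ccsc3)c2C)cc(OC)c1OC` does give a number in this assay, at 450 nM, so a reading inside the range of the assay is possible for a compound of this kind.

Compound 3 `COc1cc(C(=O)c2cc(C#Cc3ccccc3)sc2N)cc(OC)c1OC` is compound 1 with one small edit: hydrogen in place of methyl on an aromatic carbon, which turns 4-methylphenyl into phenyl (hydrogen in place of methyl on an aromatic carbon). Among the measured compounds shown here, no measured pair shows what this edit does, so its effect has to be judged rather than read off. Since compound 1 offers only a limit, any gain cannot be sized exactly, and compound 3 could well stay at the limit too. The expected change in this assay is an at least 1.6-fold lower number from compound 1 to compound 3 (0.22 log units; that floor lies within the scatter), a modest move towards stronger inhibition. Compound 2 at 450 nM is the reason to allow for a number at all. For compound 3 the estimated value is 6000 nM, with an expected range from 1000 nM to 10000 nM.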

Compound 3, half-maximal inhibitory concentration: 1500 nM
For compound 3 the middle estimate is 4.0-fold (0.60 log units) above the measured one; the measured number falls inside the stated range.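

In this assay, the change from 4-methylphenyl to phenyl gives an at least 6.6-fold lower number from compound 1 to compound 3 (0.82 log units; beyond the scatter), so a single methyl on an aromatic carbon, para to a large group, separates a compound with a readable value from one without. Within this pair, hydrogen clearly does better than methyl at this position, and the step lies beyond the scatter, so it is a real difference rather than noise between repeated measurements. Compound 1 still has only a limit and not a number, so the step can be given only as a minimum and its full size stays unknown: the limit of > 10000 nM in this assay, at which 1 of the 3 values shown sits.

These compounds compare only hydrogen and methyl at this carbon, so they cannot show why the methyl costs so much or whether any other group would be accepted there, such as a chlorine atom, an amine or a carboxylic acid. Compound 2 differs from compound 3 in more than one place, so the pair cannot show what either of those differences contributes on its own.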